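A few compounds are considered here, and "the series" means these few. Any claim that something is new, unique, unknown or untested is made for them only; others in the source may bear on it.

Measured so far in a functional assay on MCF7 cells (Homo sapiens) for inhibition, read by MTT assay, with a stated time of 72 h; on this read-out lower numbers stand for stronger inhibition and higher numbers for weaker inhibition:
- compound 1 `O=[N+]([O-])c1ccc(-c2nnc(SCCCN3CCN(c4nc5ccccc5o4)CC3)o2)cc1`: 90100 nM
- compound 2 `Brc1ccc(-c2nnc(SCCCN3CCN(c4nc5ccccc5o4)CC3)o2)cc1`: 115000 nM
- compound 3 `O=C(NCc1nnc(SCCCN2CCN(c3nc4ccccc4o3)CC2)o1)c1ccccc1`: 52700 nM

Compound 1 cannot be separated from either of the other two, since a 1.3-fold higher number from compound 1 to compound 2 (0.11 log units; within the scatter) and a 1.7-fold lower number from compound 1 to compound 3 (0.23 log units; within the scatter). Only compound 2 and compound 3 differ by more than the scatter, with a 2.2-fold lower number from compound 2 to compound 3 (0.34 log units; beyond the scatter).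

The next compound is compound 4 `O=[N+]([O-])c1ccc(-c2nnc(SCCCN3CCN(c4nc5ccccc5s4)CC3)o2)cc1`, where 1,3-benzothiazol-2-yl takes the place of 1,3-benzoxazol-2-yl on an amine nitrogen in a ring: 1,3-benzothiazol-2-yl in place of 1,3-benzoxazol-2-yl on an amine nitrogen in a ring. None of the three measured steps touches this group. All of them change a different part of the molecule, so they offer only a rough sense of how far values move in this small set, and the largest of them is modest. No step beyond the scatter is therefore expected in this assay, and the best guide is compound 1 itself at 90100 nM. The estimated step is a 1.1-fold lower number from compound 1 to compound 4 (0.03 log units; within the scatter). For compound 4 the estimated value is 85000 nM, with an expected range from 35000 nM to 200000 nM.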

Compound 4, half-maximal inhibitory concentration: 118000 nM
Estimate against measurement, compound 4: 1.4-fold (0.14 log units) below; low and high end bracket the measured number.
By their numbers in this assay, from the lowest: compounds 3, 1, 2 and 4 (each within the scatter of the next, the first and the last beyond it).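

The earlier compounds shown here all carry 1,3-benzoxazol-2-yl on the amine nitrogen of the six-membered ring, so they say nothing about this position. Compound 4 gives the first reading there: in this assay, 1,3-benzothiazol-2-yl, which has sulfur where the group it replaces has oxygen, gives a 1.3-fold higher number from compound 1 to compound 4 (0.12 log units; within the scatter), so in this single pair the exchange cannot be told apart from repeat-measurement noise. No supporting data are available to interpret this result.

The compounds shown leave open whether the same exchange would read alike with 4-bromophenyl or benzamidomethyl at the other end of the molecule, since only the 4-nitrophenyl compounds form this pair. They also leave open how a plain phenyl, a pyridine or a simple dimethylamino group would read on that ring nitrogen.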